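A few compounds are considered here, and "the series" means these few. Any claim that something is new, unique, unknown or untested is made for them only; others in the source may bear on it.

Measured compounds:
compound 1, `O=C(Nc1cccnc1)N1CCc2ccccc2[C@H]1c1ccc(C(F)(F)F)cc1`, 28 nM in an assay on isolated protein for antagonist activity at transient receptor potential cation channel subfamily M member 8 (Homo sapiens), read by luminescence and calcium flux, with a stated time of 2.5 min; a higher number here means a weaker inhibitor, a lower number a stronger inhibitor
compound 2, `O=C(Nc1ccncc1)N1CCc2ccccc2[C@H]1c1ccc(C(F)(F)F)cc1`, 398 nM

Within this pair, compound 2 holds the higher of the two numbers in this assay; its only neighbour is compound 1, and the step of a 14-fold higher number from compound 1 to compound 2 (1.15 log units; beyond the scatter) lies beyond the scatter. Compound 3, `CC(C)NC(=O)N1CCc2ccccc2[C@H]1c1ccc(C(F)(F)F)cc1`, has not yet been measured. It differs from compound 2 by isopropyl in place of pyridin-4-yl on an amide-type nitrogen. Going by the values given here, the single measured step, a 14-fold higher number from compound 1 to compound 2 (1.15 log units; beyond the scatter), concerns only where the ring nitrogen sits and does not involve an exchange of an aromatic ring for a chain, so no measured step speaks directly to the change at hand. The step of a 1.5-fold higher number from compound 2 to compound 3 (0.18 log units; within the scatter) is therefore expected only loosely, with a direction that cannot be fixed from what has been measured. For compound 3 the expected value is 600 nM, in a range from 150 nM to 2500 nM.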

Compound 3, half-maximal inhibitory concentration: 44 nM
Compound 3: middle estimate off by 14-fold (1.13 log units), on the high side; measured number below the stated range.
By their numbers in this assay, from the lowest: compounds 1 and 3 (each within the scatter of the next); then compound 2.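

In this assay, a ring on the amide-type nitrogen proves not to be required: isopropyl in place of pyridin-4-yl gives a 9.0-fold lower number from compound 2 to compound 3 (0.96 log units; beyond the scatter), and isopropyl in place of pyridin-3-yl gives only a 1.6-fold higher number from compound 1 to compound 3 (0.20 log units; within the scatter). The earlier pair showed that the ring nitrogen's location matters at this place, while the third compound shows that, among these three groups, pyridin-4-yl is the one that stands apart, since a group with no ring sits level with pyridin-3-yl. Nothing available explains why pyridin-4-yl stands apart.

The compounds shown leave open how far this tolerance extends, for example to a longer chain such as n-butyl, to a cyclopropyl or tert-butyl group, or to a plain phenyl ring. They also leave open how pyridin-2-yl would compare with its two ring isomers at this place.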